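A few compounds are considered here, and "the series" means these few. Any claim that something is new, unique, unknown or untested is made for them only; others in the source may bear on it.

Of the compounds shown here, three have been measured in a functional assay on HEK293 cells for agonist activity at D(4) dopamine receptor (Homo sapiens), read by FLIPR; a higher number here means a larger maximal response, a lower number a smaller maximal response. Compound 1 `Cc1cccc(NC(=O)CN2CCC(c3nccs3)CC2)c1` gives 62% in this assay. Compound 2 `COc1cccc(C)c1NC(=O)CN1CCC(c2cccc[n+]2[O-])CC1` gives 56%, and compound 3 `C=Cc1cccc(C(=O)NCN2CCC(c3cccc[n+]3[O-])CC2)c1` gives 63%. The number for compound 1 lies close to both of the others: its gap to compound 3 and its gap to compound 2 each fall within the usual scatter of repeated measurements, so the three cannot be told apart on maximal response. Among the measured compounds shown here, no pair among them differs in only one place, so no single structural change has yet been tied to a shift in this assay.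

Compound 4 `Cc1cccc(NC(=O)CN2CCC(c3ccc(O)cn3)CC2)c1` has not been measured. It differs from compound 1 in one place: 5-hydroxypyridin-2-yl in place of 1,3-thiazol-2-yl on a saturated ring carbon. For the measured compounds named here, nothing measured so far ties this change to a shift in maximal response, and the three known values sit in a narrow band. The step of a number 2 percentage points lower from compound 1 to compound 4 (within the scatter) is therefore expected to be small, with no direction beyond the scatter. Compound 4 is expected to give about 60% in this assay, most likely between 45% and 75%.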

Compound 4, largest response reached (reported as efficacy), in percent of the reference or control that the assay uses: 83%
Beside the measured number, compound 4's estimate is 23 percentage points below it; measured number outside the range, above it.
By their numbers in this assay, from the lowest: compounds 2, 1 and 3 (each within the scatter of the next); then compound 4.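

In this assay, placing 5-hydroxypyridin-2-yl in place of 1,3-thiazol-2-yl on the saturated ring carbon gives a number 21 percentage points higher from compound 1 to compound 4 (beyond the scatter). Among the compounds shown here, this is the first single change in the set, and it shows that the group at this position can shift the maximal response. The two groups differ in ring size, in hetero atoms and in the hydrogen-bond donor that only 5-hydroxypyridin-2-yl carries, and nothing at hand shows which of these differences matters.

The compounds shown leave open whether the hydroxyl group is needed at all, or whether a plain pyridin-2-yl ring would give the same step. They also leave open whether a methoxy group or an amine on that pyridine ring, in place of the hydroxyl, would keep the higher response.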